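Adding a hydroxy group to the side chain of compound 2

The source may hold more compounds than are shown below. What is called first, only, known or untested is meant among the compounds shown, and "the series" means these compounds.

Compound 1, `CO[C@@H]1[C@H](OC(=O)N[C@@H](C(N)=O)C(C)(C)O)CC[C@]2(CO2)[C@H]1[C@@]1(C)O[C@@H]1C[C@@H]1OC1(C)C`, gives 11.7 nM in an assay on isolated protein for inhibition of methionine aminopeptidase 2 (Homo sapiens), read by MTT assay; a lower number here means that less compound is needed, a higher number that more compound is needed for the effect.
Compound 2, `CO[C@@H]1[C@H](OC(=O)N[C@@H](C(N)=O)C(C)C)CC[C@]2(CO2)[C@H]1[C@@]1(C)O[C@@H]1C[C@H]1OC1(C)C`, gives 1.3 nM in this assay.
For compound 3, `CO[C@@H]1[C@H](OC(=O)N[C@@H](C(N)=O)C(C)C)CC[C@]2(CO2)[C@H]1[C@@]1(C)O[C@@H]1CCC(C)(C)O`, the result in this assay is "not determined" (no result reported).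

Within the data shown here, of the two numbers at hand, compound 2 stands lowest; the only other number, that of compound 1, lies higher by a margin beyond the usual scatter. Compound 1 and compound 2 differ in more than one place, so their two values show the combined effect and nothing more about any single change.

Compound 4, `CO[C@@H]1[C@H](OC(=O)N[C@@H](C(N)=O)C(C)(C)O)CC[C@]2(CO2)[C@H]1[C@@]1(C)O[C@@H]1C[C@H]1OC1(C)C`, is compound 2 with one alteration: hydroxy in place of hydrogen on a saturated chain carbon bound to three saturated chain carbons. This is the side-chain group also carried by compound 1, but compound 4 keeps the rest of compound 2 unchanged. Among the measured compounds shown here, no measured pair shows this change alone. Taken on its own, a modest rise in the number for compound 4 is expected, one that may stay within the scatter or go slightly beyond it, since compound 1, which carries this hydroxy, gives 11.7 nM. The step from compound 2 to compound 4 is expected to be a 3.1-fold higher number from compound 2 to compound 4 (0.49 log units; beyond the scatter). For compound 4 the estimate in this assay is 4 nM, with a plausible range from 1.2 nM to 14 nM.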

Compound 4, half-maximal effective concentration: 8.8 nM
Compound 4: middle estimate off by 2.2-fold (0.34 log units), on the low side; the measured number falls inside the stated range.
By their numbers in this assay, from the lowest: compound 2; then compounds 4 and 1 (each within the scatter of the next).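

In this assay, among these compounds, the change from isopropyl to 1-hydroxy-1-methylethyl, hydroxy in place of hydrogen on a saturated chain carbon bound to three saturated chain carbons, can now be read alone: it gives a 6.8-fold higher number from compound 2 to compound 4 (0.83 log units; beyond the scatter) and so shows that this single added hydroxy raises the number by itself, which the earlier compounds, differing in more than one place, could not show. The second new step reads a 1.3-fold lower number from compound 1 to compound 4 (0.12 log units; within the scatter) and so shows that, with this hydroxy present, drawing a stereocentre at a saturated ring carbon as S or as R leaves the number within the usual scatter. This second step speaks for configuration alone, and the ground for reading it that way is this: the fact that compounds 1 and 4 differ only in the configuration as drawn.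

As far as these compounds go, whether that stereocentre makes as little difference with the isopropyl group in place stays open, and compound 3, with no reported result, gives no reading of its altered chain. Also open, from the compounds shown here alone, is how an amine or a fluorine atom in place of this hydroxy would read in this assay and whether either would stay closer to compound 2.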